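This account rests on a few compounds, and the source may have more. Where it says the series, first, only, none or still open, it means among the compounds named here.

Measured compounds:
Compound 1, `O=C(COc1ccc2cc(/C=C3/SC(=O)NC3=O)ccc2c1)Nc1ccc(F)cc1F` — in an assay on isolated protein for inhibition of histone deacetylase 8 (Homo sapiens), with a stated time of 1 h (on this read-out higher numbers stand for weaker inhibition and lower numbers for stronger inhibition), compound 1 gives > 50000 nM, which is a limit of the assay and not a number.
Compound 2, `Cc1cccc2sc(NC(=O)COc3ccc4cc(/C=C5/SC(=O)NC5=O)ccc4c3)nc12` — in this assay compound 2 gives 5800 nM.

Within the data shown here, compound 2 therefore holds the only number in this set; the other value is a limit (the limit of > 50000 nM in this assay, at which 1 of the 2 values shown sits). Among the measured compounds shown here, the one measured step reads an at least 8.6-fold lower number from compound 1 to compound 2 (0.93 log units; beyond the scatter), a substituted phenyl on the amide-type nitrogen giving way to the benzothiazole.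

Compound 3, `O=C(COc1ccc2cc(/C=C3/SC(=O)NC3=O)ccc2c1)Nc1ccc(Cl)c(Cl)c1`, is yet to be measured in this assay. It differs from compound 2 by 3,4-dichlorophenyl in place of 4-methyl-1,3-benzothiazol-2-yl on an amide-type nitrogen. The measured step bears on this change in reverse: the benzothiazole that brought the improvement is removed and a phenyl returns, now 3,4-dichlorophenyl rather than the 2,4-difluorophenyl of compound 1. A higher number is therefore expected for compound 3, estimated as a 4.3-fold higher number from compound 2 to compound 3 (0.63 log units; beyond the scatter); since the phenyl is not the same as in compound 1, the full size of that step is not assumed. Compound 3 is expected at 25000 nM, with a range from 6000 nM to 100000 nM, and a real chance that only a limit is reported.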

Compound 3, half-maximal inhibitory concentration: > 50000 nM
Compound 3: no number, only a limit; the forecaster's own chance of this, stated with the estimate: 40%; at least 2.0-fold (0.30 log units) between middle value and limit.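

In this assay, replacing 4-methyl-1,3-benzothiazol-2-yl with 3,4-dichlorophenyl on the amide-type nitrogen gives an at least 8.6-fold higher number from compound 2 to compound 3 (0.93 log units; beyond the scatter), so the loss now appears with a second substituted phenyl and not only with the 2,4-difluorophenyl of compound 1. Compound 3 gives > 50000 nM, which is a limit of the assay and not a number. Among the three compounds, only the benzothiazole amide, compound 2, yields a number, while the phenyl amides, compound 1 and compound 3, both end at a limit, so the step between those two cannot be read and no order of the two phenyl patterns follows: the limit of > 50000 nM in this assay, at which 2 of the 3 values shown sit.

From the compounds shown here alone, it remains open which part of the 4-methyl-1,3-benzothiazol-2-yl group goes with the stronger inhibition, a question that a plain 1,3-benzothiazol-2-yl without the methyl or a simple thiazol-2-yl on the same nitrogen would address. Going by these compounds, it is also open whether any phenyl amide can reach a measurable number, for instance one carrying an amine or a carboxylic acid on the ring.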